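The source may hold more compounds than are shown below. What is called first, only, known or untested is meant among the compounds shown, and "the series" means these compounds.

Compound 1 `C#CCN(C)Cc1cccc(NC(=O)CCCCCCCC(=O)NO)c1` and compound 2 `C#CCN(C)Cc1cccc(NC(=O)CCCCCCCCC(=O)NO)c1` share one core, while compound 3 `C#CCN(C)Cc1ccc(NC(=O)CCCCCCC(=O)NO)cc1` is built on another; the difference between the two cores is not broken down here. In a functional assay on DU-145 cells (Homo sapiens) for inhibition, read by MTT assay, with a stated time of 48 h (on this read-out higher numbers stand for weaker inhibition of growth and lower numbers for stronger inhibition of growth), compound 1 gives 3780 nM. In this assay compound 2 gives 2940 nM. The change between them is (hydroxycarbamoyl)methyl in place of hydroxycarbamoyl on a saturated chain carbon, seven bonds along the chain from a carbonyl carbon, and the step it made is a 1.3-fold lower number from compound 1 to compound 2 (0.11 log units; within the scatter). In this assay compound 3 gives 1510 nM, the lowest of the three numbers; its gap to compound 2 lies within the scatter, its gap to compound 1 beyond it. Compound 4 `C#CCN(C)Cc1ccc(NC(=O)CCCCCCCC(=O)NO)cc1` has not yet been measured. It differs from compound 3 by (hydroxycarbamoyl)methyl in place of hydroxycarbamoyl on a saturated chain carbon, six bonds along the chain from a carbonyl carbon. Since the place is six bonds along the chain from a carbonyl carbon, where the earlier place was seven, this is the same kind of change as that from compound 1 to compound 2, not the same change. Among the measured compounds shown here, the earlier step of a 1.3-fold lower number from compound 1 to compound 2 (0.11 log units; within the scatter) lay within the scatter, and that is the only guide here. The step expected for compound 4 is therefore a 1.3-fold lower number from compound 3 to compound 4 (0.10 log units; within the scatter). In this assay compound 4 is expected to give 1200 nM, estimated between 600 nM and 2500 nM.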

Compound 4, concentration for 50% growth inhibition: 3400 nM
Beside the measured number, compound 4's estimate is 2.8-fold (0.45 log units) below it, and the stated range ends below it.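

On the core of compound 3, (hydroxycarbamoyl)methyl in place of hydroxycarbamoyl gave a 2.3-fold higher number from compound 3 to compound 4 (0.35 log units; beyond the scatter) in this assay. Set beside the same kind of change on the core of compound 1, this step does not match, so the size of the step on one core was no safe guide to its size on the other: the same change on two cores in this assay, a 1.3-fold lower number (0.11 log units; within the scatter) from compound 1 to compound 2 and a 2.3-fold higher number (0.35 log units; beyond the scatter) from compound 3 to compound 4, 2.9-fold (0.46 log units) apart, beyond the scatter of two such steps

This rests on a single pair of steps, and the place of the change also differs, seven bonds along the chain from a carbonyl carbon on one core and six on the other, so it does not show what lies behind the gap or whether it would recur on a further core.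

The compounds shown leave open how the number would move with a longer chain ending in hydroxycarbamoyl on either core. They also leave open what a carboxylic acid in place of the hydroxycarbamoyl end, or a simple methyl in place of the propargyl group on the amine, would do on these two cores.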